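Replacing the difluorophenyl ketone with a methoxyphenyl ketone

The compounds below may be only part of what the source reports. "The series", "measured", "known", "first", "only" and "open" are said of these compounds alone.

Compound 1 `COc1cc(-c2nnc3n2NC(c2ccco2)C(C(=O)c2ccccc2C)S3)cc(OC)c1OC` gives 88400 nM in a functional assay on PC-3 cells (Homo sapiens) for cytotoxicity, read by MTT assay, with a stated time of 48 h; a higher number here means a weaker inhibitor, a lower number a stronger inhibitor.
Compound 2 `COc1cc(-c2nnc3n2NC(c2ccco2)C(C(=O)c2ccccc2)S3)cc(OC)c1OC` gives 64300 nM in this assay.
Compound 3 `COc1cc(-c2nnc3n2NC(c2ccco2)C(C(=O)c2ccc(F)c(F)c2)S3)cc(OC)c1OC` gives 36000 nM in this assay.

All three share the same core and differ only in the aromatic group attached to the carbonyl carbon. Compound 3 has the lowest of the three numbers. Its nearest neighbour is compound 2, and that gap, a 1.8-fold lower number from compound 2 to compound 3 (0.25 log units; within the scatter), stays within the scatter; the gap to compound 1, a 2.5-fold lower number from compound 1 to compound 3 (0.39 log units; beyond the scatter), is the only one beyond it, and even that is modest.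

Compound 4 `COc1cccc(C(=O)C2Sc3nnc(-c4cc(OC)c(OC)c(OC)c4)n3NC2c2ccco2)c1` has not yet been measured in this assay. It differs from compound 3 in one place: 3-methoxyphenyl in place of 3,4-difluorophenyl on a carbonyl carbon. For the measured compounds named here, the steps that bear on this are the earlier swaps of the aromatic group on the same carbonyl carbon, already given, plus the small change a 1.4-fold lower number from compound 1 to compound 2 (0.14 log units; within the scatter) on an aromatic carbon of that group. None of these moved the number far, so the new swap is expected to give a step of similar size, most likely within the scatter, with no clear direction.

Compound 4 is therefore expected to give about 50000 nM, between 20000 nM and 130000 nM. The step that this estimate implies is a 1.4-fold higher number from compound 3 to compound 4 (0.14 log units; within the scatter).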

Compound 4, half-maximal inhibitory concentration: 84600 nM
Estimate against measurement, compound 4: 1.7-fold (0.23 log units) below; low and high end bracket the measured number.
By their numbers in this assay, from the lowest: compounds 3, 2, 4 and 1 (each within the scatter of the next, the first and the last beyond it).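

In this assay, 3-methoxyphenyl in place of 3,4-difluorophenyl on the carbonyl carbon gives a 2.4-fold higher number from compound 3 to compound 4 (0.37 log units; beyond the scatter) and so puts a second group, after the 2-methylphenyl of compound 1, clearly on the weaker side of the 3,4-difluorophenyl of compound 3. The methoxy group in place of hydrogen gives only a 1.3-fold higher number from compound 2 to compound 4 (0.12 log units; within the scatter) and the swap from 2-methylphenyl gives a 1.0-fold lower number from compound 1 to compound 4 (0.02 log units; within the scatter) so compound 4 cannot be told apart from compound 2 or compound 1, and the plain phenyl of compound 2 goes against any clean split because it also stays within the scatter of compound 3. Nothing measured here explains why these groups fall as they do.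

Still open, going by these compounds, is whether a single fluorine would be enough to keep the number of compound 3, or whether both fluorines are needed. An amine, a carboxylic acid or a longer chain on this aromatic ring might also move the number much further than any swap shown, or might leave it in the same range.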